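Swapping the pyrrole arm for a chlorothiazole on the sulfonamide nitrogen

This account rests on a few compounds, and the source may have more. Where it says the series, first, only, none or still open, it means among the compounds named here.

Measured compounds:
compound 1 `COc1ccc(S(=O)(=O)N(CCn2cccc2)[C@H](C)C(=O)NO)cc1`, 170 nM
compound 2 `COc1ccc(S(=O)(=O)N(Cc2ccccc2C(F)(F)F)[C@H](C)C(=O)NO)cc1`, 6 nM

In an assay on isolated protein for inhibition of bone morphogenetic protein 1 (Homo sapiens) (on this read-out higher numbers stand for weaker inhibition and lower numbers for stronger inhibition), compound 1 stands highest of the two numbers; compound 2 gives a number beyond the scatter lower. Compound 3 `COc1ccc(S(=O)(=O)N(Cc2cnc(Cl)s2)[C@H](C)C(=O)NO)cc1` differs from compound 1 by 2-chloro-1,3-thiazol-5-yl in place of (1H-pyrrol-1-yl)methyl on a saturated chain carbon bound to a sulfonamide nitrogen. Within the data shown here, no step of this kind has been measured, so the size is open. Compound 3 is expected to show a step of a 5.7-fold lower number from compound 1 to compound 3 (0.75 log units; beyond the scatter) toward a lower number, beyond the scatter, because compound 2 gives 6 nM. Compound 3 is estimated at 30 nM, within 8 nM to 120 nM.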

Compound 3, half-maximal inhibitory concentration: 180 nM
Estimate against measurement, compound 3: 6.0-fold (0.78 log units) below; measured number outside the range, above it.
By their numbers in this assay, from the lowest: compound 2; then compounds 1 and 3 (each within the scatter of the next).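

In this assay the exchange of (1H-pyrrol-1-yl)methyl for 2-chloro-1,3-thiazol-5-yl on a saturated chain carbon bound to a sulfonamide nitrogen gives a 1.1-fold higher number from compound 1 to compound 3 (0.02 log units; within the scatter) and so leaves the read-out unchanged: two different five-membered aromatic rings read alike here. Compound 2 at 6 nM alone stands apart among the three. Nothing available explains this result.
From the compounds shown here alone, what remains open is whether the low number of compound 2 belongs to its trifluoromethyl group or to its arm as a whole. A plain benzyl or a 2-chlorobenzyl group on the same nitrogen would bear on that question.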